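The source may hold more compounds than are shown below. What is called first, only, known or untested is meant among the compounds shown, and "the series" means these compounds.

Compound 3 `c1ccc(-c2ccc(Cn3cncc3CNc3ccc(-c4cc5ccccc5o4)c(-c4ccccc4)c3)cc2)cc1` is the starting point of this step. In a toxicity assay on NIH3T3 cells (Mus musculus) for cytotoxicity, read by resazurin assay (a lower number here means that less compound is needed, a higher number that more compound is needed for the effect), compound 3 gives > 10000 nM, which is a limit of the assay rather than a measured number. Two related compounds frame it. Compound 1 `c1ccc(-c2ccc(Cn3cncc3CNc3cccc(-c4ccccc4)c3)cc2)cc1` carries a hydrogen where compound 3 carries the 1-benzofuran-2-yl group, and in this assay compound 1 gives 10000 nM. Compound 2 `COC(=O)c1ccc(NCc2cncn2Cc2ccc(-c3ccccc3)cc2)cc1-c1ccccc1` carries a methoxycarbonyl group in place of that hydrogen. In this assay compound 2 gives > 1000 nM, again a limit and not a number. The steps between these three compounds are therefore hard to read: a number no lower from compound 1 to compound 3 (the limit leaves the size open), a step that the limit leaves unreadable from compound 1 to compound 2, and a step that the two limits leave unreadable from compound 2 to compound 3. The limits involved are the limit of > 1000 nM in this assay, at which 1 of the 3 values shown sits, and (the limit of > 10000 nM in this assay, at which 1 of the 3 values shown sits).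

Compound 4 `c1ccc(-c2ccc(Cn3cncc3CNc3ccc(-c4cncs4)c(-c4ccccc4)c3)cc2)cc1` differs from compound 3 in one place: 1,3-thiazol-5-yl in place of 1-benzofuran-2-yl on an aromatic carbon. Among the measured compounds shown here, none of the measured steps gives a readable size for an exchange of this kind, so there is no firm basis for expecting a shift in either direction. The step is therefore expected to stay within the usual scatter: a number no higher from compound 3 to compound 4 (the limit leaves the size open), with a real chance that only a limit is reported again. For compound 4 the estimate in this assay is 10000 nM, expected to lie between 3000 nM and 40000 nM.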

Compound 4, half-maximal effective concentration: > 1000 nM
Compound 4 ended at the assay's limit (the forecaster's own chance of this, stated with the estimate: 60%); the middle value is on the limit's open side.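

No new step can be read: the steps to compound 4 from compound 1, compound 2 and compound 3 all stay unreadable, and in this assay compound 4 gives > 1000 nM, a limit and not a number. The compounds shown leave open how much of compound 4 is needed for the effect, and whether 1,3-thiazol-5-yl in place of 1-benzofuran-2-yl shifts the number at all.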